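Methoxy for Fluoro on the Aryl Ring of Compound 2

This account rests on a few compounds, and the source may have more. Where it says the series, first, only, none or still open, it means among the compounds named here.

Measured compounds:
compound 1, `COc1cc(C(=O)/C=C/c2c(-c3cccs3)nc3ccccn23)cc(OC)c1OC`, 1880 nM
compound 2, `COc1cc(C(=O)/C=C/c2c(-c3ccc(F)cc3)nc3ncccn23)cc(OC)c1OC`, 3730 nM

Of the compounds shown here, two have been measured in a functional assay on UACC-257 cells (Homo sapiens) for inhibition, read by sulforhodamine B assay, with a stated time of 48 h; a higher number here means a weaker inhibitor of growth, a lower number a stronger inhibitor of growth. Compound 1, `COc1cc(C(=O)/C=C/c2c(-c3cccs3)nc3ccccn23)cc(OC)c1OC`, gives 1880 nM. Compound 2, `COc1cc(C(=O)/C=C/c2c(-c3ccc(F)cc3)nc3ncccn23)cc(OC)c1OC`, gives 3730 nM, the highest of the two numbers, though the gap to compound 1 is within the usual scatter, so nothing can be said about an order between them.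

The next compound, compound 3, `COc1ccc(-c2nc3ncccn3c2/C=C/C(=O)c2cc(OC)c(OC)c(OC)c2)cc1`, is derived from compound 2 by one change: methoxy in place of fluoro on an aromatic carbon. Within the data shown here, the change sits on an aromatic carbon of a six-membered aromatic ring of carbon only, and nothing among the measured compounds shows what such a change does in this assay, since the two measured compounds differ in more than one place.

Among the measured compounds shown here, with no comparable step to lean on, compound 3 is expected to stay near compound 2, with a step of a 1.2-fold lower number from compound 2 to compound 3 (0.09 log units; within the scatter) that would not go beyond the scatter. Compound 3 is therefore estimated at 3000 nM, with a range from 1200 nM to 7500 nM.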

Compound 3, concentration for 50% growth inhibition: 1820 nM
Compound 3: middle estimate off by 1.6-fold (0.22 log units), on the high side, within the range that was stated.
By their numbers in this assay, from the lowest: compounds 3, 1 and 2 (each within the scatter of the next, the first and the last beyond it).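

In this assay, among these compounds, the change from 4-fluorophenyl to 4-methoxyphenyl provides the first reading of a single change in this set, a 2.0-fold lower number from compound 2 to compound 3 (0.31 log units; beyond the scatter), and that step lies beyond the scatter. It shows that the position para to a large group on this aromatic ring responds to a substitution, which the earlier pair could not show because compound 1 and compound 2 differ in more than one place. The size of the step is modest, and nothing shown here accounts for it.

On these data alone, what remains open is whether this step is particular to methoxy or whether other groups at the same place, such as an amine, a hydroxyl group, a carboxylic acid or a longer alkoxy chain, would move the number in the same direction or the opposite one. As far as these compounds go, it is also open whether the change from fluoro to methoxy would give a similar step on the core of compound 1, or whether this single step holds only on the core shared by compound 2 and compound 3.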